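Series notes: (4-cyanophenyl)sulfonyl replacing (2-phenylethenyl)carbonyl on the ring nitrogen

The compounds below may be only part of what the source reports. "The series", "measured", "known", "first", "only" and "open" are said of these compounds alone.

Compound 1 `CN(C)c1ccc(C2CC(c3ccc(-n4cncn4)cc3)=NN2)cc1` carries a hydrogen on the ring nitrogen of the shared core; in a functional assay on MDA-MB-231 cells (Homo sapiens) for inhibition, read by sulforhodamine B assay, tested at 10 uM (a lower number here means less inhibition, a higher number more inhibition at the concentration tested (going by the name of the read-out)), compound 1 gives 7%. Compound 2 `CN(C)c1ccc(C2CC(c3ccc(-n4cncn4)cc3)=NN2C(=O)c2ccc(F)cc2)cc1` gives 12.5%, and compound 3 `CN(C)c1ccc(C2CC(c3ccc(-n4cncn4)cc3)=NN2C(=O)/C=C/c2ccccc2)cc1` gives 8.5%. Compound 3 thus stands second highest of the three numbers, with compound 1 nearest and compound 2 furthest, both within the scatter. The measured steps are a number 5.5 percentage points higher from compound 1 to compound 2 (within the scatter), a number 1.5 percentage points higher from compound 1 to compound 3 (within the scatter) and a number 4 percentage points lower from compound 2 to compound 3 (within the scatter); none leaves the scatter, so substitution on the ring nitrogen has not moved the read-out in any direction that can be trusted.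

Compound 4 `CN(C)c1ccc(C2CC(c3ccc(-n4cncn4)cc3)=NN2S(=O)(=O)c2ccc(C#N)cc2)cc1` is the next member. The change is (4-cyanophenyl)sulfonyl in place of (2-phenylethenyl)carbonyl on an amine nitrogen in a ring. Among the measured compounds shown here, all three measured steps bear on it in that they alter the same ring nitrogen, yet no measured compound carries a sulfonyl or a nitrile, so the new group is untested here. Given that every step at this position stayed within the scatter, the expected step is a number 1.5 percentage points higher from compound 3 to compound 4 (within the scatter), i.e. none beyond the scatter. For compound 4 the estimate in this assay is 10%, expected to fall between 0% and 25%.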

Compound 4, a percentage reported as inhibition, at one concentration (the size of the read-out at that concentration, not a potency): 32.8%
Beside the measured number, compound 4's estimate is 22.8 percentage points below it; the measured number lies above the stated range.
By their numbers in this assay, from the lowest: compounds 1, 3 and 2 (each within the scatter of the next); then compound 4.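

In this assay, the ring nitrogen no longer looks like a silent position: the (4-cyanophenyl)sulfonyl group gives a number 24.3 percentage points higher from compound 3 to compound 4 (beyond the scatter), a number 20.3 percentage points higher from compound 2 to compound 4 (beyond the scatter) and a number 25.8 percentage points higher from compound 1 to compound 4 (beyond the scatter), whereas hydrogen and the two carbonyl-linked groups stay within the scatter of one another. Compound 4 therefore stands above all three earlier compounds, though each step is only modest, and the read-out at this nitrogen does respond to the group placed there. No available evidence accounts for this step.

The change brings in the sulfonyl and the nitrile together, so the compounds shown cannot say which of the two carries the step, or whether it needs both. A phenylsulfonyl group on the same nitrogen would test the sulfonyl without the nitrile, a (4-cyanophenyl)carbonyl group would test the nitrile without the sulfonyl, and a methylsulfonyl group would ask whether the aromatic ring on the sulfonyl is needed at all.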